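Methyl to bromo on two cores: cytotoxicity working notes

This account rests on a few compounds, and the source may have more. Where it says the series, first, only, none or still open, it means among the compounds named here.

Compound 1 `Cc1ccccc1/C=C/c1ncc([N+](=O)[O-])n1C` and compound 2 `Cn1c([N+](=O)[O-])cnc1/C=C/c1ccccc1Br` share one core; compound 3 `CC(=O)OC(c1ccc(C)cc1)C(OC(C)=O)c1ncc([N+](=O)[O-])n1C` and compound 4 `CC(=O)OC(c1ccc(Br)cc1)C(OC(C)=O)c1ncc([N+](=O)[O-])n1C` share another, and the difference between the two cores is not broken down here. In an ADME assay on HeLa cells (Homo sapiens) for cytotoxicity, read by resazurin assay, with a stated time of 2 days (on this read-out lower numbers stand for stronger inhibition and higher numbers for weaker inhibition), compound 1 gives 93300 nM. In this assay compound 2 gives 72400 nM. The change bromo in place of methyl on an aromatic carbon produced a 1.3-fold lower number from compound 1 to compound 2 (0.11 log units; within the scatter). For compound 3 only a limit is reported in this assay, namely > 100000 nM, the limit described in the limit of > 100000 nM in this assay, at which 1 of the 3 values shown sits. The change bromo in place of methyl on an aromatic carbon is the same kind of change as the one made on the first core, but here the entering group stands para to a large group, where on the first core it stood ortho to a large group. For compound 4 the expected step is a number no higher from compound 3 to compound 4 (the limit leaves the size open), resting on the earlier step of a 1.3-fold lower number from compound 1 to compound 2 (0.11 log units; within the scatter) that stayed within the scatter. Compound 4 is therefore estimated at 100000 nM, and a limit rather than a number is the more likely outcome.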

Compound 4, half-maximal inhibitory concentration: 97700 nM
Beside the measured number, compound 4's estimate is 1.0-fold (0.01 log units) above it; the range from low to high includes it.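

Compound 3 is reported only as a limit in this assay: the limit of > 100000 nM in this assay, at which 1 of the 4 values shown sits.

Going by these compounds, on the second core, bromo in place of methyl gives an at least 1.0-fold lower number from compound 3 to compound 4 (0.01 log units; that floor lies within the scatter), and only this floor can be read, so the full size of the step stays unknown. Set beside the first core, the result is compatible with the change carrying over between the two cores, but it does not establish this, and a larger step on the second core is not ruled out: the same change on two cores in this assay, a 1.3-fold lower number (0.11 log units; within the scatter) from compound 1 to compound 2 and an at least 1.0-fold lower number (0.01 log units; that floor lies within the scatter) from compound 3 to compound 4; the limit leaves it open whether they differ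

Still open, on these data alone, is whether a different group on the same aromatic carbon, such as an amine, a carboxylic acid or a methoxy group, would give a step that can be read in full on both cores. Each core also shows the change in one place on its ring only, so the pairs shown cannot separate the effect of the core from that of the place.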